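From 3-Chlorophenyl to 4-Methylphenyl on the Ether Oxygen

The source may report more compounds than this note shows. Statements on the series, on what has been measured and on what is new or still open speak of the compounds shown alone.

Compound 1 `NC1=NC2(CCOCC2)N(OCCCOc2ccc(Cl)cc2Cl)C(N)=N1` — > 90%
Compound 2 `NC1=NC2(CCOCC2)N(OCCCOc2cccc(Cl)c2)C(N)=N1` — 83.2%

In an assay on isolated protein for inhibition of Dihydrofolate reductase (Homo sapiens), read by spectrophotometry, using NADPH, with stated times of 5 s and 6 min, tested at 5 uM (on this read-out lower numbers stand for a weaker effect and higher numbers for a stronger effect at the one concentration tested), compound 1 gives > 90%, which is a limit of the assay and not a number (the limit of > 90% in this assay, at which 1 of the 2 values shown sits). Compound 2 gives 83.2% in this assay; the step of a number at least 6.8 percentage points lower from compound 1 to compound 2 (that floor lies within the scatter). Compound 2 therefore holds the only number shown in this assay; the further value is a limit.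

Compound 3 `Cc1ccc(OCCCON2C(N)=NC(N)=NC23CCOCC3)cc1` differs from compound 2 in one place: 4-methylphenyl in place of 3-chlorophenyl on an oxygen on a saturated carbon. For the measured compounds named here, the only measured step, a number at least 6.8 percentage points lower from compound 1 to compound 2 (that floor lies within the scatter), alters the same phenyl ring, but its floor lies within the scatter and no measured step exchanges a chloro substituent for a methyl, so it gives little guidance. The step from compound 2 to compound 3 in this assay is expected to be a number 8.2 percentage points lower from compound 2 to compound 3 (within the scatter), none beyond the scatter. Compound 3 is estimated at 75% in this assay, within 55% to 92%.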

Compound 3, a percentage reported as inhibition, at one concentration (the size of the read-out at that concentration, not a potency): > 90%
Compound 3 ended at the assay's limit; the forecaster's own chance of this, stated with the estimate: 10%; at least 15 percentage points between middle value and limit.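

In this assay compound 3 gives > 90%, which is a limit of the assay and not a number. For the compounds shown here, the exchange of 3-chlorophenyl for 4-methylphenyl on an oxygen on a saturated carbon gives a number at least 6.8 percentage points higher from compound 2 to compound 3 (that floor lies within the scatter), and it shows what the earlier compounds did not: a phenyl ring carrying no chlorine can also reach the limit of this read-out. The step from compound 1 to compound 3 cannot be read, and the two compounds cannot be ordered: the limit of > 90% in this assay, at which 2 of the 3 values shown sit.

The compounds shown leave open whether a carboxylic acid or an amine on the phenyl ring, or a longer chain in place of the present one, would keep the read-out at this limit. They also leave open whether compound 1 or compound 3 would show the stronger effect at a lower concentration.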